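A Second Chloro Group and Expected Tolerance in Cells

The source may hold more compounds than are shown below. What is called first, only, known or untested is meant among the compounds shown, and "the series" means these compounds.

Compound 1 `NC(=S)N/N=C(/COc1ccc(Br)cc1)c1ccccc1` and compound 2 `NC(=S)N/N=C(/COc1ccc(Br)cc1)c1ccc(Cl)cc1` share one core and differ by chloro in place of hydrogen on an aromatic carbon. In an ADME assay on L929 cells (Mus musculus) for cytotoxicity, read by resazurin assay, with a stated time of 96 h (a lower number here means that less compound is tolerated, a higher number that more compound is tolerated), compound 1 gives < 27500 nM, which is a limit of the assay rather than a number. In this assay compound 2 gives 25100 nM. The step that the limit leaves unreadable from compound 1 to compound 2 therefore has no readable size, as the limit of < 27500 nM in this assay, at which 1 of the 3 values shown sits, shows.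

Compound 3 `NC(=S)N/N=C(\COc1cccc(Cl)c1)c1ccc(Br)cc1` has a different core; how the two cores differ is not broken down here. In this assay compound 3 gives < 50200 nM, again a limit of the assay and not a number, as the limit of < 50200 nM in this assay, at which 1 of the 3 values shown sits, records. Compound 4 `NC(=S)N/N=C(\COc1cccc(Cl)c1Cl)c1ccc(Br)cc1` is not yet measured and differs from compound 3 by chloro in place of hydrogen on an aromatic carbon. This is the same kind of change as from compound 1 to compound 2, but not the same: there the entering chloro sat para to a large group, here it sits ortho to a chloro group and ortho to a large group. With compound 1 left at a limit, the earlier step offers no size to lean on. Compound 4 is expected to sit at 15000 nM, between 5000 nM and 45000 nM. For the measured compounds named here, this amounts to an expected step that the limit leaves unreadable from compound 3 to compound 4, resting on the one measured number, that of compound 2 at 25100 nM.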

Compound 4, half-maximal cytotoxic concentration: 23100 nM
Compound 4: middle estimate off by 1.5-fold (0.19 log units), on the low side, within the range that was stated.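

No size can be read for the step from compound 3 to compound 4, because compound 3 gives only a limit of the assay and not a number: the limit of < 50200 nM in this assay, at which 1 of the 4 values shown sits.

The compounds shown leave open whether chloro in place of hydrogen on an aromatic carbon changes how much compound is tolerated in this assay, either from compound 1 to compound 2 or from compound 3 to compound 4.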